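The compounds below may be only part of what the source reports. "The series", "measured", "known", "first", "only" and "open" are said of these compounds alone.

Compound 1 `O=c1c2c(C(F)(F)F)cc(-c3ccccc3)nc2ncn1Cc1cn(CCC(F)(F)C(F)(F)C(F)(F)C(F)(F)C(F)(F)C(F)(F)C(F)(F)C(F)(F)F)nn1` and compound 2 `CCc1nc2nc(-c3ccccc3)cc(C(F)(F)F)c2c(=O)n1Cc1cn(CCC(F)(F)C(F)(F)C(F)(F)C(F)(F)C(F)(F)C(F)(F)C(F)(F)C(F)(F)F)nn1` are the measured pair in a functional assay on THP-1 cells (Homo sapiens) for cytotoxicity, read by MTT assay, with a stated time of 24 h; on this read-out higher numbers stand for weaker inhibition and lower numbers for stronger inhibition. Compound 1 gives 79.1 ug/mL in this assay. For compound 2 the read-out in this assay is a limit, > 200 ug/mL. The step of an at least 2.5-fold higher number from compound 1 to compound 2 (0.40 log units; beyond the scatter) therefore rests on (the limit of > 200 ug/mL in this assay, at which 1 of the 2 values shown sits). Compound 3 `CC(C)c1nc2nc(-c3ccccc3)cc(C(F)(F)F)c2c(=O)n1Cc1cn(CCC(F)(F)C(F)(F)C(F)(F)C(F)(F)C(F)(F)C(F)(F)C(F)(F)C(F)(F)F)nn1` carries methyl in place of hydrogen on a saturated chain carbon bound to an aromatic carbon and a saturated chain carbon. Among the measured compounds shown here, only that one measured step bears on this change. It ran toward weaker inhibition, and compound 2 already sits at the limit. The expected step that the limit leaves unreadable from compound 2 to compound 3 is none beyond the scatter. Compound 3 is expected at 250 ug/mL in this assay, within 120 ug/mL to 500 ug/mL, most likely again as a limit.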

Compound 3, half-maximal inhibitory concentration: 142 ug/mL
Beside the measured number, compound 3's estimate is 1.8-fold (0.25 log units) above it; measured number inside the range.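

Ethyl to isopropyl gives an at least 1.4-fold lower number from compound 2 to compound 3 (0.14 log units; that floor lies within the scatter) in this assay, so this added methyl brings no step beyond the scatter that can be claimed. Isopropyl in place of hydrogen on the aromatic carbon gives a 1.8-fold higher number from compound 1 to compound 3 (0.25 log units; within the scatter), so compound 3 is not separated from compound 1, and the step seen with ethyl does not recur with isopropyl. The true size of the ethyl to isopropyl step stays unknown, since compound 2 is read only as a limit: the limit of > 200 ug/mL in this assay, at which 1 of the 3 values shown sits.

Going by these compounds, how a longer chain such as n-butyl, or an amine, would read at this position remains open.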